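Swapping Hydroxy for Trifluoromethyl on the Aryl Ketone

The compounds below may be only part of what the source reports. "The series", "measured", "known", "first", "only" and "open" are said of these compounds alone.

Of the compounds shown here, three have been measured, all on one shared core. Compound 1 `COc1cc(-c2nnc3n2NC(c2ccco2)C(C(=O)C2CC2)S3)cc(OC)c1OC` gives only a limit in a functional assay on A549 cells (Homo sapiens) for cytotoxicity, read by MTT assay, with a stated time of 48 h (a higher number here means a weaker inhibitor, a lower number a stronger inhibitor), > 100000 nM. Compound 2 `COc1cc(-c2nnc3n2NC(c2ccco2)C(C(=O)c2ccc(F)c(F)c2)S3)cc(OC)c1OC` gives 93700 nM. Compound 3 `COc1cc(-c2nnc3n2NC(c2ccco2)C(C(=O)c2ccc(O)cc2)S3)cc(OC)c1OC` gives 93400 nM.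

Compound 3 holds the lowest of the two numbers, but its nearest neighbour sits within the scatter: a 1.0-fold lower number from compound 2 to compound 3 (0.00 log units; within the scatter). Compound 4 `COc1cc(-c2nnc3n2NC(c2ccco2)C(C(=O)c2ccc(C(F)(F)F)cc2)S3)cc(OC)c1OC` differs from compound 3 by trifluoromethyl in place of hydroxy on an aromatic carbon. The measured steps that bear on exchanging the group on the carbonyl carbon are an at least 1.0-fold lower number from compound 1 to compound 2 (0.02 log units; that floor lies within the scatter), an at least 1.0-fold lower number from compound 1 to compound 3 (0.02 log units; that floor lies within the scatter) and a 1.0-fold lower number from compound 2 to compound 3 (0.00 log units; within the scatter); the first two start from a limit (the limit of > 100000 nM in this assay, at which 1 of the 3 values shown sits), and none reaches beyond the scatter. A step in this assay is therefore expected to stay within the scatter. For compound 4 the expected value is 90000 nM, within 40000 nM to 200000 nM. The expected step is a 1.0-fold lower number from compound 3 to compound 4 (0.02 log units; within the scatter).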

Compound 4, half-maximal inhibitory concentration: 37200 nM
Estimate against measurement, compound 4: 2.4-fold (0.38 log units) above; measured number outside the range, below it.
By their numbers in this assay, from the lowest: compound 4; then compounds 3 and 2 (each within the scatter of the next). At a limit, above all of these: compound 1.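

Here, for the first time, exchanging the group on the carbonyl carbon moves the number beyond the scatter in this assay, with a 2.5-fold lower number from compound 3 to compound 4 (0.40 log units; beyond the scatter) and a 2.5-fold lower number from compound 2 to compound 4 (0.40 log units; beyond the scatter). The step from the cyclopropyl ketone reads an at least 2.6-fold lower number from compound 1 to compound 4 (0.42 log units; beyond the scatter). Compound 1 gives only a limit, so that step is a floor: the limit of > 100000 nM in this assay, at which 1 of the 4 values shown sits.

The compounds shown leave open whether the lower number comes from gaining trifluoromethyl or from losing hydroxy. On these data alone, how a methyl group, an amine or a carboxylic acid on that same aromatic carbon would read also stays unknown.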